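Fluorine for methyl on the cyclobutyl amide of compound 3

The source may hold more compounds than are shown below. What is called first, only, known or untested is meant among the compounds shown, and "the series" means these compounds.

Compound 1, `CC(=O)N1CCc2nc(C#Cc3ccccc3)sc2C1` — > 10000 nM in an assay on HEK293 cells for positive allosteric modulation of metabotropic glutamate receptor 5 (Homo sapiens), read by FLIPR, with a stated time of 1 h; a lower number here means that less compound is needed, a higher number that more compound is needed for the effect
Compound 2, `CCC(=O)N1CCc2nc(C#Cc3ccccc3)sc2C1` — > 10000 nM in this assay
Compound 3, `CC1CC(C(=O)N2CCc3nc(C#Cc4ccccc4)sc3C2)C1` — 81 nM in this assay

The three measured compounds share one core and differ only in the group on the carbonyl carbon of the amide. For compound 1 the value in this assay is a limit of the assay, not a number. For compound 2 it is likewise a limit. Compound 3 is the only compound with a number shown, and the step of an at least 120-fold lower number from compound 1 to compound 3 (2.09 log units; beyond the scatter) as well as an at least 120-fold lower number from compound 2 to compound 3 (2.09 log units; beyond the scatter) are both large, with the two limits at the limit of > 10000 nM in this assay, at which 2 of the 3 values shown sit, marking where the smaller amides sit.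

Compound 4, `O=C(C1CC(F)C1)N1CCc2nc(C#Cc3ccccc3)sc2C1`, has not been measured. It differs from compound 3 in one place: fluoro in place of methyl on a saturated ring carbon. Going by the values given here, no measured step changes a substituent on the cyclobutyl ring, so none bears directly on this change; the measured steps concern only the size of the group on the carbonyl carbon, which is kept here. Compound 4 is therefore expected to stay near compound 3, with a 1.9-fold higher number from compound 3 to compound 4 (0.27 log units; within the scatter), a step of modest size at most. The estimate for compound 4 is 150 nM, within 40 nM to 600 nM.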

Compound 4, half-maximal effective concentration: 85 nM
Beside the measured number, compound 4's estimate is 1.8-fold (0.25 log units) above it, within the range that was stated.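

Compound 4 changes a substituent on the cyclobutyl ring itself, and in this assay that change at the saturated ring carbon gives a small step: a 1.0-fold higher number from compound 3 to compound 4 (0.02 log units; within the scatter). The large distance from the smaller amides therefore appears with 3-fluorocyclobutyl as it does with 3-methylcyclobutyl, and it does not depend on the methyl group of compound 3: an at least 110-fold lower number from compound 2 to compound 4 (2.07 log units; beyond the scatter), and an at least 110-fold lower number from compound 1 to compound 4 (2.07 log units; beyond the scatter). Both of these steps are measured against limits of the assay and not against numbers: the limit of > 10000 nM in this assay, at which 2 of the 4 values shown sit.

The compounds shown leave open how a hydroxyl, an amine or a carboxylic acid on the same ring carbon would read, and whether the ring needs a substituent there at all. They also leave open how a cyclopropyl or cyclopentyl group, or a longer chain, on the carbonyl carbon would compare.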